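This account rests on a few compounds, and the source may have more. Where it says the series, first, only, none or still open, it means among the compounds named here.

Working notes on a series of amides sharing one core and varied at a single aromatic carbon. Compound 3 `CCCCCc1cc(C(F)(F)F)ccc1CNC(=O)C(C)c1ccc(NS(C)(=O)=O)c(F)c1` stands lowest of the three measured compounds in an assay on CHO cells for antagonist activity at transient receptor potential cation channel subfamily V member 1 (Homo sapiens), read by FLIPR (a higher number here means a weaker inhibitor, a lower number a stronger inhibitor), and gives 0.4 nM. Compound 2 `CC(C(=O)NCc1ccc(C(F)(F)F)cc1OCc1ccccc1)c1ccc(NS(C)(=O)=O)c(F)c1` gives 0.9 nM in this assay, and compound 1 `CC(C(=O)NCc1ccc(C(F)(F)F)cc1N1CCN(c2ccccc2)CC1)c1ccc(NS(C)(=O)=O)c(F)c1` gives 2 nM. The measured steps are all modest and all point the same way: a 2.3-fold lower number from compound 2 to compound 3 (0.35 log units; beyond the scatter), a 5.0-fold lower number from compound 1 to compound 3 (0.70 log units; beyond the scatter), and a 2.2-fold lower number from compound 1 to compound 2 (0.35 log units; beyond the scatter). Both substituents that carry a ring give a higher number than pentyl.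

Compound 4 `CC(C(=O)NCc1ccc(C(F)(F)F)cc1-c1ccc(F)c(Cl)c1)c1ccc(NS(C)(=O)=O)c(F)c1` is not yet measured in this assay. The change from compound 3 is 3-chloro-4-fluorophenyl in place of pentyl on an aromatic carbon. For the measured compounds named here, no measured step exchanges pentyl for a directly attached aromatic ring, so the nearest guides are the steps from compound 2 and from compound 1 to compound 3, both modest and both with pentyl on the lower side. A modest rise from compound 3 is therefore expected, of about a 2.5-fold higher number from compound 3 to compound 4 (0.40 log units; beyond the scatter). For compound 4 the estimated value in this assay is 1 nM, with an expected range from 0.3 nM to 4 nM.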

Compound 4, inhibition constant: 0.6 nM
Compound 4: the middle estimate sits 1.7-fold (0.22 log units) above what was measured; the measured number falls inside the stated range.
By their numbers in this assay, from the lowest: compounds 3, 4 and 2 (each within the scatter of the next, the first and the last beyond it); then compound 1.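

A directly attached aromatic ring is accepted at this aromatic carbon in this assay: 3-chloro-4-fluorophenyl cannot be told apart from pentyl (a 1.5-fold higher number from compound 3 to compound 4 (0.18 log units; within the scatter)) or from benzyloxy (a 1.5-fold lower number from compound 2 to compound 4 (0.18 log units; within the scatter)), so carrying a ring does not by itself separate a substituent from pentyl here. Only 4-phenylpiperazin-1-yl stands apart from 3-chloro-4-fluorophenyl (a 3.3-fold lower number from compound 1 to compound 4 (0.52 log units; beyond the scatter)), and compound 1 is thus beyond the scatter from each of the other three compounds. No measurement available here bears on the reason for these numbers.

The compounds shown leave open what the chlorine and the fluorine contribute, as an unsubstituted phenyl does not stand among them. Also open, going by these compounds, is how a primary amine, a carboxylic acid or a chain longer than pentyl would read at this aromatic carbon.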